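The source may report more compounds than this note shows. Statements on the series, on what has been measured and on what is new or still open speak of the compounds shown alone.

In a physicochemical assay for lipophilicity, at pH 7.4 (on this read-out lower numbers stand for lower lipophilicity and higher numbers for higher lipophilicity), compound 1 `CCc1ccc(N(CC(C)C)S(=O)(=O)c2ccc3c(c2)C(=O)CC(CC2CCOCC2)O3)cc1` gives 4.53 and compound 2 `CCc1ccc(N(CC(C)C)S(=O)(=O)c2ccc3c(c2)C(=O)CC(C(C)C2CCOCC2)O3)cc1` gives 4.93 as the higher of the two numbers. Compound 3 `CCc1ccc(N(CC(C)C)S(=O)(=O)c2ccc3c(c2)C(=O)CC(C2(C)CCOCC2)O3)cc1` differs from compound 2 4-methyloxan-4-yl in place of 1-(oxan-4-yl)ethyl on a saturated ring carbon with 4-methyloxan-4-yl in place of 1-(oxan-4-yl)ethyl on a saturated ring carbon. Going by the values given here, only one measured step bears on this: a number 0.40 log units higher from compound 1 to compound 2 (beyond the scatter) came with methyl in place of hydrogen on a saturated chain carbon. That rise was modest but beyond the scatter. The entering group here has fewer heavy atoms, so a fall of similar size is expected, and the estimated step is a number 0.33 log units lower from compound 2 to compound 3 (beyond the scatter) in this assay overall. For compound 3 the estimate is 4.6 with an expected range from 4.25 to 4.95 at this stage.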

Compound 3, distribution coefficient: 4.71
Compound 3: the middle estimate sits 0.11 log units below what was measured, and the stated range covers the measured number.
By their numbers in this assay, from the lowest: compounds 1, 3 and 2 (each within the scatter of the next, the first and the last beyond it).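

In this assay, 4-methyloxan-4-yl in place of 1-(oxan-4-yl)ethyl gives a number 0.22 log units lower from compound 2 to compound 3 (within the scatter) and 4-methyloxan-4-yl in place of (oxan-4-yl)methyl gives a number 0.18 log units higher from compound 1 to compound 3 (within the scatter) at this saturated ring carbon. Compound 3 therefore cannot be separated from either neighbour, even though compound 1 and compound 2 lie beyond the scatter of each other. No measurement shown explains this outcome.

Still open is how an amine or a carboxylic acid on this ring carbon would read in this assay as a measure of these compounds.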